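This account rests on a few compounds, and the source may have more. Where it says the series, first, only, none or still open, it means among the compounds named here.

Measured so far in a functional assay on PANC-1 cells (Homo sapiens) for inhibition, read by MTT assay, with a stated time of 48 h; on this read-out lower numbers stand for stronger inhibition and higher numbers for weaker inhibition:

- compound 1 `Cc1nnsc1CO/N=C/c1c(C)nn(C)c1Oc1ccc(OC(F)(F)F)cc1`: > 50000 nM, a limit of the assay
- compound 2 `CCc1nnsc1CO/N=C/c1c(C)nn(C)c1Oc1ccc(OC(F)(F)F)cc1`: > 50000 nM, a limit of the assay
- compound 3 `Cc1nnsc1CO/N=C/c1c(C)nn(C)c1Cl`: 26600 nM

Compound 1 and compound 2 are joined by the change (methyl in place of hydrogen on a saturated chain carbon bound to an aromatic carbon). The step that the two limits leave unreadable from compound 1 to compound 2 cannot be read, because both of its ends sit at the limit of > 50000 nM in this assay, at which 2 of the 3 values shown sit. Compound 3 carries a different core; the difference between the two cores is not broken down here. Going by the values given here, compound 3 gives the only number in this assay.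

Compound 4 `CCc1nnsc1CO/N=C/c1c(C)nn(C)c1Cl` is not yet measured. Among the compounds with values here, it differs from compound 3 by methyl in place of hydrogen on a saturated chain carbon bound to an aromatic carbon, the same change as the one from compound 1 to compound 2, at the same place. That earlier step gives no readable size, so nothing here points to a large effect either way. The step of a 1.1-fold higher number from compound 3 to compound 4 (0.05 log units; within the scatter) is therefore expected to stay within the usual scatter. For compound 4 the expected value is 30000 nM, with a range from 12000 nM to 70000 nM.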

Compound 4, half-maximal inhibitory concentration: > 50000 nM
Compound 4: a limit, no number; the forecaster's own chance of this, stated with the estimate: 35%; middle value at least 1.6-fold (0.22 log units) from the limit.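

In this assay compound 4 gives > 50000 nM, a limit of the assay and not a number. On the core of compound 3, methyl in place of hydrogen on a saturated chain carbon bound to an aromatic carbon gives an at least 1.8-fold higher number from compound 3 to compound 4 (0.27 log units; that floor lies within the scatter), so the change reads only as a floor, and the pair is not shown to separate beyond the usual scatter. The same change on the core of compound 1 cannot be read, so no comparison of its size between the two cores exists and carry-over is neither shown nor excluded, and the limit recurs: the limit of > 50000 nM in this assay, at which 3 of the 4 values shown sit.

Open, from the compounds shown here alone, is whether a longer chain such as propyl, or an amine, at this place would give a readable number on either core. Also open, going by these compounds, is how much of the gap between the two cores belongs to the core itself.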